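Extending the chain on the ring nitrogen once more

A few compounds are considered here, and "the series" means these few. Any claim that something is new, unique, unknown or untested is made for them only; others in the source may bear on it.

Compound 1 `N#CCn1c(=N)sc2cc(OC(F)(F)F)ccc21` is the starting point; in a functional assay on the whole organism with Rattus norvegicus as the target (a lower number here means that less compound is needed, a higher number that more compound is needed for the effect), compound 1 gives 3.5 mg/kg. Compound 2 `C[S+]([O-])Cn1c(=N)sc2cc(OC(F)(F)F)ccc21` carries a different group on the same saturated chain carbon bound to the aromatic nitrogen, and in this assay compound 2 gives 2.3 mg/kg. The step of a 1.5-fold lower number from compound 1 to compound 2 (0.18 log units; within the scatter) shows that this exchange left the number essentially unchanged, so compound 2 stands beside compound 1 and nothing in these two numbers separates them. Compound 3 `CS(=O)(=O)CCCn1c(=N)sc2cc(OC(F)(F)F)ccc21` is the unmeasured analogue, with a group of 6 heavy atoms (3 carbon, 2 oxygen, 1 sulfur; no ring) in place of a group of 3 heavy atoms (1 carbon, 1 oxygen, 1 sulfur; no ring), on a saturated chain carbon bound to an aromatic nitrogen. Among the compounds with values here, the only step that bears on it is the one from compound 1 to compound 2, which altered the same place and stayed within the scatter; the new change is larger, yet nothing measured points in either direction. Compound 3 is therefore expected to show no step beyond the scatter, a 1.1-fold higher number from compound 2 to compound 3 (0.05 log units; within the scatter), giving an estimated 2.6 mg/kg with a range from 1.2 mg/kg to 5.5 mg/kg.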

Compound 3, dose for half-maximal effect: 5 mg/kg
For compound 3 the middle estimate is 1.9-fold (0.28 log units) below the measured one; measured number inside the range.
By their numbers in this assay, from the lowest: compounds 2, 1 and 3 (each within the scatter of the next, the first and the last beyond it).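

Within the data shown here, on the saturated chain carbon bound to an aromatic nitrogen, the exchange of the group of compound 2 for 2-(methylsulfonyl)ethyl gives the first step beyond the scatter in this assay (a 2.2-fold higher number from compound 2 to compound 3 (0.34 log units; beyond the scatter)), and that step is modest. The same group in place of cyano stays within the scatter (a 1.4-fold higher number from compound 1 to compound 3 (0.15 log units; within the scatter)), so this position accepts a group of 6 heavy atoms without a clear separation from the nitrile-bearing compound. No available evidence accounts for the step between the other pair.

The whole group changes between compound 2 and compound 3, so these numbers cannot separate the effect of the longer chain from that of the change at sulfur. As far as these compounds go, how an amine, a carboxylic acid or a longer chain ending in methylsulfonyl would fare at this position remains open.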